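This account rests on a few compounds, and the source may have more. Where it says the series, first, only, none or still open, it means among the compounds named here.

Values in a functional assay on A549 cells (Homo sapiens) for inhibition, read by CCK-8 assay, with a stated time of 48 h; a lower number here means a stronger inhibitor, a higher number a weaker inhibitor:
- compound 1 `COc1cc(-c2ccnc3cc(-c4ccc5c(ccn5C)c4)nn23)cc(OC)c1OC`: 15 nM
- compound 2 `COc1cc(-c2ccnc3cc(-c4ccc(N(C)C)cc4)nn23)cc(OC)c1OC`: 1100 nM
- compound 3 `C=Cc1ccc(-c2cc3nccc(-c4cc(OC)c(OC)c(OC)c4)n3n2)cc1`: 1030 nM

Compound 3 gives 1030 nM and belongs to the weak pair of the three. Inside that pair the measured step is a 1.1-fold lower number from compound 2 to compound 3 (0.03 log units; within the scatter), so the two cannot be told apart. Among the measured compounds shown here, the distance to the one strong value is a 69-fold higher number from compound 1 to compound 3 (1.84 log units; beyond the scatter).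

The next structure is compound 4 `COc1cc(-c2ccnc3cc(-c4ccc5cnn(C)c5c4)nn23)cc(OC)c1OC`, with 1-methyl-1H-indazol-6-yl in place of 4-vinylphenyl on an aromatic carbon. In words, 1-methyl-1H-indazol-6-yl stands in place of 4-vinylphenyl on an aromatic carbon.

For the measured compounds named here, the steps that bear on this are a 69-fold higher number from compound 1 to compound 3 (1.84 log units; beyond the scatter) and a 73-fold higher number from compound 1 to compound 2 (1.87 log units; beyond the scatter). Both replace 1-methyl-1H-indol-5-yl with a substituted phenyl, and both are large. Compound 4 runs the other way, leaving a substituted phenyl for a methylated two-ring group, so a move toward a lower number is expected. However, no measured compound carries 1-methyl-1H-indazol-6-yl, and it is not the group of compound 1, so only part of that distance is expected to be recovered. In this assay the expected change is a 15-fold lower number from compound 3 to compound 4 (1.17 log units; beyond the scatter), a step beyond the scatter.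

For compound 4 the estimated value is 70 nM, with an expected range of 12 nM to 400 nM.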

Compound 4, half-maximal inhibitory concentration: 233 nM
For compound 4 the middle estimate is 3.3-fold (0.52 log units) below the measured one, and the stated range covers the measured number.
By their numbers in this assay, from the lowest: compound 1; then compound 4; then compounds 3 and 2 (each within the scatter of the next).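

In this assay, the position on an aromatic carbon of a five-membered aromatic ring with 2 nitrogen no longer divides the series into only one strong and two weak compounds: 1-methyl-1H-indazol-6-yl gives a 4.4-fold lower number from compound 3 to compound 4 (0.65 log units; beyond the scatter) and a 4.7-fold lower number from compound 2 to compound 4 (0.67 log units; beyond the scatter), both modest steps that place this group apart from both substituted phenyl groups. The two methylated two-ring groups are still not equivalent at this position, as a 16-fold higher number from compound 1 to compound 4 (1.19 log units; beyond the scatter) is a large step, so a second aromatic ring alone does not reproduce the level of compound 1, and the change from 1-methyl-1H-indol-5-yl to 1-methyl-1H-indazol-6-yl alters both the ring atoms and the point of attachment. No measured data here explain any of these steps.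

The compounds shown leave open whether the ring atoms or the point of attachment account for the gap to compound 1, a question that 1-methyl-1H-indazol-5-yl or 1-methyl-1H-indol-6-yl at the same position would address. Going by these compounds, it also remains open whether the methyl on the two-ring groups matters, as the unmethylated 1H-indol-5-yl group would show.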